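A few compounds are considered here, and "the series" means these few. Any claim that something is new, unique, unknown or untested is made for them only; others in the source may bear on it.

Measured in a functional assay on MCF7 cells (Homo sapiens) for cytotoxicity, read by WST assay, with a stated time of 72 h; a lower number here means a stronger inhibitor, a higher number a weaker inhibitor:
- compound 1 `O=C1Nc2c(ccc(F)c2F)C1(c1ccccc1)c1ccc(O)cc1` gives 7.1 nM
- compound 2 `O=C1Nc2c(ccc(F)c2F)C1(c1ccc(O)cc1)c1ccc(F)c(F)c1` gives 7.8 nM
- compound 3 `CCCCCC1(c2ccc(O)cc2)C(=O)Nc2c1ccc(F)c2F` gives 96 nM

Compound 3 has the highest number of the three and is the weakest here. Its pentyl chain replaces the aromatic rings of the other two, giving a 14-fold higher number from compound 1 to compound 3 (1.13 log units; beyond the scatter) and a 12-fold higher number from compound 2 to compound 3 (1.09 log units; beyond the scatter), both large. Changing one of those aromatic rings for the other gives only a 1.1-fold higher number from compound 1 to compound 2 (0.04 log units; within the scatter), within the scatter.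

Compound 4 `O=C1Nc2c(ccc(F)c2F)C1(CC1CCCCC1)c1ccc(O)cc1` differs from compound 3 by cyclohexyl in place of butyl on a saturated chain carbon bound to a saturated ring carbon. Read one bond further out, this is pentyl to cyclohexylmethyl. For the measured compounds named here, no measured step makes this exact change, and no measured compound carries a non-aromatic ring, so the two large steps are only a loose guide. A ring at the end of the chain may recover a small part of the lost strength, though a step within the scatter remains possible. The expected change is a 2.1-fold lower number from compound 3 to compound 4 (0.33 log units; beyond the scatter), a modest move towards a lower number. The estimate for compound 4 is 45 nM, with an expected range from 12 nM to 150 nM.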

Compound 4, half-maximal inhibitory concentration: 102 nM
The estimate for compound 4 lay 2.3-fold (0.36 log units) below the measured number; measured number inside the range.
By their numbers in this assay, from the lowest: compounds 1 and 2 (each within the scatter of the next); then compounds 3 and 4 (each within the scatter of the next).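

Going from pentyl to cyclohexylmethyl gives a 1.1-fold higher number from compound 3 to compound 4 (0.03 log units; within the scatter) and the two groups cannot be told apart. Against the aromatic groups, cyclohexylmethyl gives a 13-fold higher number from compound 2 to compound 4 (1.12 log units; beyond the scatter) and a 14-fold higher number from compound 1 to compound 4 (1.16 log units; beyond the scatter) so a non-aromatic ring in this place does not bring back the low numbers of compound 1 and compound 2. Nothing available here explains these results.

Open, as far as these compounds go, is whether a benzyl group, with its aromatic ring held one carbon away, or a cyclohexyl group placed directly on the saturated ring carbon would give low numbers.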